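The source may hold more compounds than are shown below. What is called first, only, known or untested is meant among the compounds shown, and "the series" means these compounds.

Two compounds have been measured so far in a physicochemical assay for acid dissociation, and they give these values:

- compound 1 `NS(=O)(=O)c1ccc(S(=O)(=O)CCO)c(F)c1` (9)
- compound 2 `COC(=O)c1cc(S(N)(=O)=O)ccc1S(=O)(=O)CCO` (9.2)

Compound 2 (9.2) and compound 1 (9) lie within the scatter of each other, so neither can be ranked above the other.

The next compound to be measured is compound 3 `Nc1cc(S(N)(=O)=O)ccc1S(=O)(=O)CCO` which has amino in place of methoxycarbonyl on an aromatic carbon of compound 2 (amino in place of methoxycarbonyl on an aromatic carbon). This carbon is ortho to a (2-hydroxyethyl)sulfonyl group and meta to a sulfamoyl group.

Among the measured compounds shown here, one measured step bears on this change, an exchange of methoxycarbonyl for fluoro on an aromatic carbon (a number 0.20 log units higher from compound 1 to compound 2 (within the scatter)). For the measured compounds named here, it stayed within the scatter, but it is a single step and no measured compound carries amino, so it is only a thin guide. The step (a number 0.10 log units higher from compound 2 to compound 3 (within the scatter)) is therefore expected to stay within the scatter of this assay with no firm direction.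

Compound 3 is estimated at (9.3) with an expected range (8.9 to 9.7).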

Compound 3, acid dissociation constant: 9.5
Compound 3: middle estimate off by 0.20 log units, on the low side, within the range that was stated.
By their numbers in this assay, from the lowest: compounds 1, 2 and 3 (each within the scatter of the next, the first and the last beyond it).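

In this assay, among the compounds shown here, amino on this aromatic carbon, ortho to a (2-hydroxyethyl)sulfonyl group and meta to a sulfamoyl group, gives the first step at this position that lies beyond the scatter, with amino in place of fluoro (a number 0.50 log units higher from compound 1 to compound 3 (beyond the scatter)), although that step is modest. The exchange of methoxycarbonyl for amino stays within the scatter (a number 0.30 log units higher from compound 2 to compound 3 (within the scatter)), so compound 2 cannot be separated from either compound 1 or compound 3, and only the comparison of amino with fluoro shows that the group on this carbon can register in this read-out. No measurement of any property of these groups is available to account for either step.

Three groups on one carbon cannot show whether a hydroxyl, a carboxylic acid or a dimethylamino group there would stand with amino, with fluoro or apart from both. On these data alone, it also remains open whether the step from fluoro to amino would hold with a longer chain in place of the 2-hydroxyethyl on the sulfonyl group.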